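Replacing a piperidine amide with a tert-butyl amide

A few compounds are considered here, and "the series" means these few. Any claim that something is new, unique, unknown or untested is made for them only; others in the source may bear on it.

Compound 1, `COC(=O)C1=C(C)NC(C)=C(C(=O)OC)C1c1ccc(OCC(=O)N2CCCC(C)C2)c(OC)c1`, gives 10000 nM in an assay on cells for inhibition of Voltage-gated L-type calcium channel (Rattus norvegicus), read by fluorescence and calcium flux, with stated times of 30 min and 2 min; a higher number here means a weaker inhibitor, a lower number a stronger inhibitor.
Compound 2, `COC(=O)C1=C(C)NC(C)=C(C(=O)OC)C1c1cccc(OCC(=O)N2CCCCC2)c1`, gives 10000 nM in this assay.

Compound 1 stands level with compound 2 at the digits shown; the two values lie within the scatter of each other, so the numbers say nothing about any order between them. Both show only weak inhibition in this assay.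

Compound 3, `COC(=O)C1=C(C)NC(C)=C(C(=O)OC)C1c1ccc(OCC(=O)NC(C)(C)C)c(OC)c1`, is the unmeasured member. It differs from compound 1 in one place: (tert-butyl)amino in place of 3-methylpiperidin-1-yl on a carbonyl carbon. For the measured compounds named here, no pair of measured compounds shares this change, so there is no measured step to lean on. The two values on hand both sit at the same weak level, and nothing in them points to a direction for the new amide. The expectation is therefore that the step from compound 1 to compound 3 in this assay is none beyond the scatter, no change at the digits printed from compound 1 to compound 3 (within the scatter). On that basis compound 3 is estimated at 10000 nM, with a range from 5000 nM to 20000 nM, and with a fair chance that the assay again returns only a ceiling rather than a number.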

Compound 3, half-maximal inhibitory concentration: 2500 nM
Compound 3: the middle estimate sits 4.0-fold (0.60 log units) above what was measured; the whole stated range lies above it.
By their numbers in this assay, from the lowest: compound 3; then compounds 1 and 2 (each within the scatter of the next).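

In this assay, the amide on the ((3-methylpiperidin-1-yl)carbonyl)methoxy arm proves able to move the reading: (tert-butyl)amino in place of 3-methylpiperidin-1-yl on a carbonyl carbon gives a 4.0-fold lower number from compound 1 to compound 3 (0.60 log units; beyond the scatter), a modest step that lies beyond the scatter and points towards stronger inhibition. The earlier compounds shown here, both ring amides, stood level and gave no sign that this position could shift the number at all. The change removes the ring and brings in a hydrogen-bond donor, but nothing measured here ties the step to either of these features or to anything else about the new group.

The compounds shown leave open whether the gain follows the amide hydrogen, the open branched shape of tert-butyl or simply the loss of the 3-methylpiperidin-1-yl ring. Cyclohexylamino would keep the amide hydrogen with a ring on the nitrogen and dimethylamino would give an open amide without that hydrogen, so this pair of groups would begin to pull those possibilities apart.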